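This account rests on a few compounds, and the source may have more. Where it says the series, first, only, none or still open, it means among the compounds named here.

Measured compounds in the series:

compound 1 `Cc1c(Cc2ccccc2S(=O)(=O)c2ccccc2F)c2c(n1CC(=O)O)CCNC2=O` gives 3.6 nM
compound 2 `Cc1c(Cc2ccccc2S(=O)(=O)N2CCOCC2)c2c(n1CC(=O)O)CCNC2=O` gives 22 nM

Compound 1 is the stronger of the two in a functional assay on CHO.K1 cells for antagonist activity at prostaglandin D2 receptor 2 (Homo sapiens), read by GTPgammaS binding, with a stated time of 1 h; on this read-out lower numbers stand for stronger inhibition and higher numbers for weaker inhibition. For the measured compounds named here, compound 2 holds the highest number of the two measured; the only measured step is a 6.1-fold higher number from compound 1 to compound 2 (0.79 log units; beyond the scatter), which places compound 2 well apart from compound 1.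

Compound 3 `Cc1c(Cc2ccccc2C(=O)c2ccccc2)c2c(n1CC(=O)O)CCNC2=O` is not yet measured. It differs from compound 2 by benzoyl in place of (morpholin-4-yl)sulfonyl on an aromatic carbon, on an aromatic carbon of a six-membered aromatic ring of carbon only, ortho to a large group. The measured step bears on this change only in part: the step of a 6.1-fold higher number from compound 1 to compound 2 (0.79 log units; beyond the scatter) shows that a six-membered aromatic ring of carbon only on the sulfonyl sulfur gives a lower number than morpholin-4-yl in that position. Going by the values given here, compound 3 carries a benzoyl, which again presents a six-membered aromatic ring of carbon only at this place, though with a carbonyl rather than a sulfonyl as the link; no measured pair tests that exchange of link. The expected step is therefore a fall in the number in this assay, of about the size seen for compound 1 relative to compound 2, but with wide uncertainty. For compound 3 the estimate is 6 nM, range 2 nM to 25 nM, a step of a 3.7-fold lower number from compound 2 to compound 3 (0.56 log units; beyond the scatter) that is expected rather than known.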

Compound 3, half-maximal inhibitory concentration: 810 nM
Estimate against measurement, compound 3: 140-fold (2.13 log units) below; measured number outside the range, above it.
By their numbers in this assay, from the lowest: compound 1; then compound 2; then compound 3.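

In this assay, the exchange of a sulfonyl-based group for benzoyl on this aromatic carbon carries a large penalty: benzoyl in place of (morpholin-4-yl)sulfonyl gives a 37-fold higher number from compound 2 to compound 3 (1.57 log units; beyond the scatter), and benzoyl in place of (2-fluorophenyl)sulfonyl gives a 230-fold higher number from compound 1 to compound 3 (2.35 log units; beyond the scatter). A six-membered aromatic ring of carbon only at this place therefore does not by itself give a low number: compound 1 and compound 3 both carry such a ring, yet compound 3 lies well above compound 2, which has a morpholine ring there instead. The data offer no explanation for this result, and no independent measurement bears on it.

The compounds shown leave open how much of the step to compound 3 belongs to the loss of the sulfonyl and how much to the loss of the fluorine, since compound 1 and compound 3 differ in both; a 2-fluorobenzoyl or an unsubstituted phenylsulfonyl group would separate the two. A morpholine-4-carbonyl group would likewise show whether a carbonyl link is as poor without the phenyl ring of compound 3.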